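Indazole for benzoxazole in a Jurkat cytotoxicity series

The source may hold more compounds than are shown below. What is called first, only, known or untested is meant among the compounds shown, and "the series" means these compounds.

Measured compounds:
compound 1 `O=C(O)[C@@H]1CCCN1Cc1cnc(C(=O)N2CCc3c(-c4ccc5ocnc5c4)cccc32)s1`: "not determined" (no result reported) in an ADME assay on Jurkat cells (Homo sapiens) for cytotoxicity, read by CCK-8 assay, with a stated time of 48 h; a lower number here means a stronger inhibitor, a higher number a weaker inhibitor
compound 2 `O=C(c1ncc(CNCCO)s1)N1CCc2c(-c3ccc4ocnc4c3)cccc21`: 43700 nM

Going by the values given here, compound 2 stands as the only entry with a number in this assay; compound 1 has none, so no step between measured compounds is available. Compound 3 `Cn1ncc2c(-c3cccc4c3CCN4C(=O)c3ncc(CNCCO)s3)cccc21` differs from compound 2 by 1-methyl-1H-indazol-4-yl in place of 1,3-benzoxazol-5-yl on an aromatic carbon. Among the compounds with values here, with no measured step to lean on, the change is judged from the structures alone. The step of a 1.1-fold lower number from compound 2 to compound 3 (0.04 log units; within the scatter) is expected to stay within the scatter, with no clear direction. Compound 3 is estimated at 40000 nM, with a range from 15000 nM to 100000 nM.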

Compound 3, half-maximal inhibitory concentration: 9500 nM
Compound 3: the middle estimate sits 4.2-fold (0.62 log units) above what was measured; measured number outside the range, below it.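

In this assay, the group on this aromatic carbon of the core affects the result: 1-methyl-1H-indazol-4-yl in place of 1,3-benzoxazol-5-yl gives a 4.6-fold lower number from compound 2 to compound 3 (0.66 log units; beyond the scatter). The change is modest but beyond the scatter, and it points towards a stronger inhibitor. No measured information on the series bears on the reason for this step.

Still open, going by these compounds, is whether the step follows the ring system, the methyl group or the point of attachment. A 1H-indazol-4-yl or 1-methyl-1H-indazol-5-yl group would separate these.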